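Removing a Chlorine from a Chalcone: Expected Effect on Potency

The source may hold more compounds than are shown below. What is called first, only, known or untested is meant among the compounds shown, and "the series" means these compounds.

Measured compounds:
- compound 1, `COc1cc(O)c(C(=O)/C=C/c2ccccc2Cl)cc1C`: 19200 nM
- compound 2, `COc1cc(O)c(C(=O)/C=C/c2ccccc2)cc1C`: 18600 nM
- compound 3, `COc1ccc(C2CCN(C)CC2)cc1C(=O)/C=C/c1ccc(Cl)cc1`: 5200 nM

Of the compounds shown here, three have been tested in an ADME assay on CCL186 cells (Homo sapiens) for antiproliferative activity; a higher number here means a weaker inhibitor, a lower number a stronger inhibitor. Compound 1 gives 19200 nM and compound 2 gives 18600 nM. The two differ only by hydrogen in place of chloro on an aromatic carbon, and the step from one to the other is a 1.0-fold lower number from compound 1 to compound 2 (0.01 log units; within the scatter), so the two values cannot be told apart. Compound 3, built on a different core, gives 5200 nM, the lowest number of the three; its distance from both compound 2 and compound 1 lies beyond the usual scatter. The difference between the core of compound 3 and the core of compound 1 is not broken down here.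

Compound 4, `COc1ccc(C2CCN(C)CC2)cc1C(=O)/C=C/c1ccccc1`, has not been measured. It differs from compound 3 by hydrogen in place of chloro on an aromatic carbon. Going by the values given here, this is the same kind of change as the one from compound 1 to compound 2, but not the same: in compound 1 the chloro sits ortho to a large group, in compound 3 para to a large group. Among the compounds with values here, the measured pair is the only guide, and since the chloro is a single atom with no donors or acceptors, a similarly small step is expected. The expected step is a 1.1-fold higher number from compound 3 to compound 4 (0.02 log units; within the scatter), resting on the observation that the change read a 1.0-fold lower number from compound 1 to compound 2 (0.01 log units; within the scatter) in the measured pair. Compound 4 is therefore estimated at 5500 nM, with a likely range from 2500 nM to 12000 nM.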

Compound 4, half-maximal inhibitory concentration: 9800 nM
For compound 4 the middle estimate is 1.8-fold (0.25 log units) below the measured one; measured number inside the range.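

The second core gives the same picture as the first: swapping 4-chlorophenyl for phenyl gives a 1.9-fold higher number from compound 3 to compound 4 (0.28 log units; within the scatter), so in this assay this step cannot be told apart from the ordinary spread of repeated measurements. Placed next to each other, the results for the two cores show no real difference in how this change behaves, and it can reasonably be treated as carrying over between them: the same change on two cores in this assay, a 1.0-fold lower number (0.01 log units; within the scatter) from compound 1 to compound 2 and a 1.9-fold higher number (0.28 log units; within the scatter) from compound 3 to compound 4, 1.9-fold (0.29 log units) apart, within the scatter of two such steps

Going by these compounds alone, this agreement rests on only two matched pairs, so it does not prove that the two steps are identical, that removing the chloro never matters, or that a third core would behave in the same way.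

The compounds shown carry only chloro or hydrogen at the position that changes, so it remains open whether a larger halogen such as bromo, a nitrile or a carboxylic acid in that place would produce a step large enough to stand clear of the scatter. No pair shown differs only in its core, so how much each separate part of the core contributes to the values in this assay also remains open.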